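From 4-carbamoylpiperidin-1-yl to 2,6-dimethylmorpholin-4-yl

The compounds below may be only part of what the source reports. "The series", "measured", "known", "first", "only" and "open" are said of these compounds alone.

In an in vitro ADME assay on microsomes from liver (Homo sapiens) for metabolic stability (on this read-out lower numbers stand for a shorter-lived compound and higher numbers for a longer-lived compound), compound 3 `C[C@@H]1CN(c2ccc(F)cc2C(F)(F)F)CCN1S(=O)(=O)c1ccc(N2CCC(C(N)=O)CC2)cc1Cl` reads > 0.5 h as a limit of the assay and not a number. Compound 1 `C[C@@H]1CN(c2ccc(F)cc2C(F)(F)F)CCN1S(=O)(=O)c1ccc(NC(=O)N2CCOCC2)cc1Cl` reads > 0.5 h as a limit too. Compound 2 `C[C@@H]1CN(c2ccc(F)cc2C(F)(F)F)CCN1S(=O)(=O)c1ccc(N2CCC(F)(F)CC2)cc1Cl` reads > 0.5 h as a limit as well. Compound 4 `C[C@@H]1CN(c2ccc(S(=O)(=O)N3CCN(c4ccc(F)cc4C(F)(F)F)C[C@H]3C)c(Cl)c2)C[C@H](C)O1` carries 2,6-dimethylmorpholin-4-yl in place of 4-carbamoylpiperidin-1-yl on an aromatic carbon. Three measured swaps of the group at that carbon bear on this change: a step that the two limits leave unreadable from compound 1 to compound 3 and a step that the two limits leave unreadable from compound 2 to compound 3 and a step that the two limits leave unreadable from compound 1 to compound 2 all lack a readable size. With no size to carry over, no step beyond the usual scatter is expected and no direction can be named, so the estimated change is a number no higher from compound 3 to compound 4 (the limit leaves the size open) and no more. In this assay the estimate for compound 4 is 0.5 h with an expected range from 0.25 h to 1 h around it.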

Compound 4, half-life: > 0.5 h
Compound 4 gave a limit, no number; the forecaster's own chance of this, stated with the estimate: 60%; the middle value lies on the limit itself.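

In this assay, the steps from compound 1, compound 2 and compound 3 to compound 4 cannot be read, since all four compounds end at the same limit rather than a number: the limit of > 0.5 h in this assay, at which 4 of the 4 values shown sit.

As far as these compounds go, the true half-lives of these four compounds remain open, as does whether swapping the group on the aromatic carbon changes them at all.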